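Moving the chlorine on the benzyl ring of compound 3

This account rests on a few compounds, and the source may have more. Where it says the series, first, only, none or still open, it means among the compounds named here.

Measured so far:
- compound 1, `Nc1nc(NCc2ccccc2F)nc(-c2ccccc2CO)n1`, 4.27
- compound 2, `Nc1nc(NCc2ccc(F)cc2)nc(-c2ccccc2CO)n1`, 3.97
- compound 3, `Nc1nc(NCc2ccccc2Cl)nc(-c2ccccc2CO)n1`, 5.07

All three compounds share one core and differ only in the substituted benzyl group attached to a ring nitrogen. They were tested in a functional assay on cells for positive allosteric modulation of G-protein coupled receptor 68 (Homo sapiens), read by a luciferase reporter and cAMP accumulation, with a stated time of 30 min, at pH 6.8 and pH 8.3, in the presence of a further agent that is not named here; a higher number here means a more potent compound, by a factor of ten per unit of this negative logarithm, a lower number a less potent compound. Compound 3 stands highest of the three numbers: the step of a number 0.80 log units higher from compound 1 to compound 3 (beyond the scatter) is beyond the scatter, and the step of a number 1.10 log units higher from compound 2 to compound 3 (beyond the scatter) is larger still. Compound 4, `Nc1nc(NCc2cccc(Cl)c2)nc(-c2ccccc2CO)n1`, has not yet been measured. It keeps the same atoms as compound 3 but joins them differently: 3-chlorophenyl in place of 2-chlorophenyl on a saturated chain carbon bound to a nitrogen on an aromatic ring.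

The step that bears most directly on this change is the one in which the halogen was moved around the ring with the halogen kept the same: a number 0.30 log units lower from compound 1 to compound 2 (within the scatter), which is within the scatter. The two chloro-containing steps, from compound 1 and from compound 2 to compound 3, both changed the halogen itself and so say less about position alone. For the measured compounds named here, the one positional step points to little change or a small drop. Compound 4 is therefore expected to show a number 0.37 log units lower from compound 3 to compound 4 (beyond the scatter), with an estimated value of 4.7, in a range from 4.1 to 5.3.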

Compound 4, negative logarithm of the antagonist equilibrium constant: 4.97
Beside the measured number, compound 4's estimate is 0.27 log units below it; the range from low to high includes it.
By their numbers in this assay, from the lowest: compounds 2 and 1 (each within the scatter of the next); then compounds 4 and 3 (each within the scatter of the next).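

In this assay, the two chlorinated benzyl groups cannot be told apart (a number 0.10 log units lower from compound 3 to compound 4 (within the scatter)), so on this saturated chain carbon, 2-chlorophenyl and 3-chlorophenyl give results that match within the usual variation between repeat measurements. The earlier compounds shown here showed a chlorophenyl group at only one arrangement, whereas compound 4 shows that the advantage over the two fluorinated compounds is not confined to that arrangement (a number 1.00 log units higher from compound 2 to compound 4 (beyond the scatter) and a number 0.70 log units higher from compound 1 to compound 4 (beyond the scatter)), although each of these two steps alters both the halogen and its place on the ring, so neither isolates one from the other. Nothing measured alongside these potency numbers explains why the two chlorophenyl compounds match or why they stand clear of the fluorophenyl compounds.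

The compounds shown leave open whether this tolerance extends beyond chlorine, for instance to a bromophenyl group, or to a benzyl ring carrying an amine or a carboxylic acid. They also leave open what a longer chain between the ring and the nitrogen on the shared core would do to the potency seen with compound 3 and compound 4.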